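A few compounds are considered here, and "the series" means these few. Any claim that something is new, unique, unknown or untested is made for them only; others in the source may bear on it.

In a functional assay on M4E cells (Homo sapiens) for cytotoxicity, read by resazurin assay, with a stated time of 72 h (a lower number here means a stronger inhibitor, a higher number a weaker inhibitor), compound 1 `O=C(/C=C/c1ccc(OCCCCO[N+](=O)[O-])c(O)c1)OCCCCO[N+](=O)[O-]` gives > 50000 nM, which is a limit of the assay and not a number. Compound 3 `COc1cc(/C=C/C(=O)OCc2ccc(OCc3c(-c4ccccc4)no[n+]3[O-])cc2)ccc1O` gives > 50000 nM, which is also a limit. Within the data shown here, compound 2 `O=C(/C=C/c1ccc(O)c(O)c1)OCc1c(-c2ccccc2)no[n+]1[O-]` gives 12900 nM, the only actual number in this small set. Compound 1 therefore stands at the limit of > 50000 nM in this assay, at which 2 of the 3 values shown sit, so its true position is not known.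

The next compound to be tested is compound 4 `COc1cc(/C=C/C(=O)OCCCCO[N+](=O)[O-])ccc1OCCCCO[N+](=O)[O-]`. It departs from compound 1 by one change, methyl in place of hydrogen on an oxygen on an aromatic ring, or hydroxy to methoxy. Among the measured compounds shown here, no measured pair in the set isolates this change. The expectation therefore rests on the position of compound 1 at the limit of > 50000 nM in this assay, at which 2 of the 3 values shown sit. The expected step is a number no higher from compound 1 to compound 4 (the limit leaves the size open), and no shift beyond the scatter is anticipated, with a further reading at the limit the likeliest result. For compound 4 the estimated value is 50000 nM, with an expected range from 20000 nM to 100000 nM.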

Compound 4, half-maximal inhibitory concentration: > 50000 nM
Compound 4: no number, only a limit; the forecaster's own chance of this, stated with the estimate: 75%; the middle value sits exactly at the limit.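

In this assay compound 1 and compound 4 both give only a limit and not a number, so no step can be read between them: the limit of > 50000 nM in this assay, at which 3 of the 4 values shown sit. The compounds shown leave open whether methyl in place of hydrogen on an oxygen on an aromatic ring changes the true value at all.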